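Replacing the whole amine substituent on a shared core

This account rests on a few compounds, and the source may have more. Where it says the series, first, only, none or still open, it means among the compounds named here.

Compound 1 `Cc1cc(C)c(-n2c(Cl)cn3c(CN(CCC(F)(F)F)CC4CC4)c(C(F)(F)F)nc23)c(C)c1` is measured in an assay on cells for displacement of a labelled ligand from corticotropin-releasing factor receptor 1 (Homo sapiens), with a stated time of 100 min (a lower number here means a stronger inhibitor, a higher number a weaker inhibitor), at 16 nM, the lowest of the two numbers shown. For the measured compounds named here, compound 2 `Cc1cc(C)c(-n2c(Cl)cn3c(CN(CCC(F)(F)F)Cc4ccccc4)c(C(F)(F)F)nc23)c(C)c1` gives 43 nM in this assay, and the step of a 2.7-fold higher number from compound 1 to compound 2 (0.43 log units; beyond the scatter) is the only measured change that bears on the present question. Compound 3 `Cc1cc(C)c(-n2c(Cl)cn3c(CN(C)Cc4ccco4)c(C(F)(F)F)nc23)c(C)c1` differs from compound 1 by ((furan-2-yl)methyl)(methyl)amino in place of (cyclopropylmethyl)(3,3,3-trifluoropropyl)amino on a saturated chain carbon bound to an aromatic carbon. Going by the values given here, the change is larger than the one from compound 1 to compound 2: besides an aromatic ring taking the place of cyclopropyl, the 3,3,3-trifluoropropyl chain gives way to methyl, and no measured pair shows what that second part does. Since an aromatic ring in place of cyclopropyl already weakened binding in the step of a 2.7-fold higher number from compound 1 to compound 2 (0.43 log units; beyond the scatter), a step of similar or somewhat greater size toward a higher number is expected for compound 3, giving a 3.1-fold higher number from compound 1 to compound 3 (0.49 log units; beyond the scatter). Compound 3 is therefore estimated at 50 nM, within a range of 15 nM to 170 nM.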

Compound 3, inhibition constant: 180 nM
For compound 3 the middle estimate is 3.6-fold (0.56 log units) below the measured one; measured number above the stated range.
By their numbers in this assay, from the lowest: compound 1; then compound 2; then compound 3.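

In this assay the exchange of the whole amine substituent gives an 11-fold higher number from compound 1 to compound 3 (1.05 log units; beyond the scatter), a clearly larger change than a 2.7-fold higher number from compound 1 to compound 2 (0.43 log units; beyond the scatter) seen when only the cyclopropyl group gives way to a phenyl group. The substituent on this saturated chain carbon bound to an aromatic carbon is therefore not interchangeable, and an aromatic ring in place of cyclopropyl does not by itself set the size of the loss seen here. Nothing measured alongside these binding numbers accounts for the larger step.

Still open, as far as these compounds go, is how much of the step belongs to methyl replacing 3,3,3-trifluoropropyl and how much to the furan-2-yl ring, as both change together in compound 3. Equally open, from the compounds shown here alone, is whether an n-propyl chain in place of that methyl would recover binding.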